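Swapping a Naphthyl Arm for a Trifluoromethylphenyl Arm

This account rests on a few compounds, and the source may have more. Where it says the series, first, only, none or still open, it means among the compounds named here.

Compound 1 `Cc1cc(-c2ccccc2)n(/C(N)=N/S(=O)(=O)c2cc(C)c(Cl)cc2SCc2cccc3ccccc23)n1` has the highest number of the two compounds measured in an ADME assay on microsomes from liver (Homo sapiens) for metabolic stability, read by LC-MS, using NADPH, tested at 5 uM; a lower number here means that the compound disappears faster, a higher number that the compound lasts longer; in this assay compound 1 gives 0.256 h. Among the measured compounds shown here, the only other measured compound, compound 2 `Cc1cc(S(=O)(=O)/N=C(\N)n2nccc2-c2ccccc2)c(SCc2ccccc2)cc1Cl`, gives 0.0772 h in this assay, a number some way lower than that of compound 1, beyond the usual scatter; compound 2 differs from compound 1 in more than one place, so its value says nothing direct about any single change.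

Compound 3 `Cc1cc(-c2ccccc2)n(/C(N)=N/S(=O)(=O)c2cc(C)c(Cl)cc2SCc2ccc(C(F)(F)F)cc2)n1` is made from compound 1 by one change: 4-(trifluoromethyl)phenyl in place of naphthalen-1-yl on a saturated chain carbon bound to a sulfur. For the measured compounds named here, no measured pair isolates this change, so the step from compound 1 to compound 3 in this assay can only be guessed. Compound 3 is expected to stay within the scatter of compound 1, with an expected step of a 1.2-fold lower number from compound 1 to compound 3 (0.07 log units; within the scatter). Compound 3 is thus estimated at 0.22 h, in a range from 0.09 h to 0.55 h.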

Compound 3, half-life: 0.241 h
The estimate for compound 3 lay 1.1-fold (0.04 log units) below the measured number, and the stated range covers the measured number.
By their numbers in this assay, from the lowest: compound 2; then compounds 3 and 1 (each within the scatter of the next).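

Among the compounds shown here, this is the first pair of compounds that differ in one place only, and in this assay it gives a 1.1-fold lower number from compound 1 to compound 3 (0.03 log units; within the scatter). On this saturated chain carbon bound to a sulfur, 4-(trifluoromethyl)phenyl can therefore stand in place of naphthalen-1-yl with no difference that can be told apart from the scatter, even though one aromatic ring replaces two and the heavy-atom count stays the same. Nothing available explains why these two groups give such similar numbers.

The compounds shown leave open whether this tolerance extends to very different groups at this place, such as a carboxylic acid or an amine. They also leave open whether the same swap would give a similar result on a core other than that of compound 1.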